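Tetrazole to Pyrazole on a Urea Scaffold

The compounds below may be only part of what the source reports. "The series", "measured", "known", "first", "only" and "open" are said of these compounds alone.

Compound 1 `Cc1cc(C)c(NC(=O)N(Cc2cccc(-c3nnnn3C)c2)C2CCCCCC2)c(C)c1` was tested in a functional assay on a cell-free system (plasma) with sterol O-acyltransferase, Soat (Rattus norvegicus) as the target; on this read-out higher numbers stand for an effect only at larger amounts of compound and lower numbers for an effect already at smaller amounts. Compound 1 reaches only a limit of that assay, > 1 mg/kg, so no exact number is known for it. Compound 2 `Cc1cc(C)c(NC(=O)N(Cc2ccccc2)Cc2cccc(-c3cc[nH]n3)c2)c(C)c1` also ends at a limit in this assay, > 1 mg/kg. Compound 3 `CN(C)c1ccc(CN(Cc2cccc(-c3cc[nH]n3)c2)C(=O)Nc2c(F)cc(F)cc2F)cc1` sits at the opposite limit of this assay, < 0.32 mg/kg. Two of the three values thus rest at the limit of > 1 mg/kg in this assay, at which 2 of the 3 values shown sit, and one at the limit of < 0.32 mg/kg in this assay, at which 1 of the 3 values shown sits. Compound 4 `Cc1cc(C)c(NC(=O)N(Cc2cccc(-c3ccn(C)n3)c2)C2CCCCCC2)c(C)c1` differs from compound 1 by 1-methyl-1H-pyrazol-3-yl in place of 1-methyl-1H-tetrazol-5-yl on an aromatic carbon. Going by the values given here, no measured pair shows this change, so compound 4 is expected to stay close to compound 1, with a step that the limit leaves unreadable from compound 1 to compound 4 not beyond the usual scatter. For compound 4 the estimate in this assay is 1.5 mg/kg, within 0.4 mg/kg to 5 mg/kg.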

Compound 4, dose for half-maximal effect: < 1 mg/kg
Compound 4: a limit, no number; the forecaster's own chance of this, stated with the estimate: 60%; at least 1.5-fold (0.17 log units) between middle value and limit.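

In this assay compound 4 gives < 1 mg/kg, a limit and not a number. Putting 1-methyl-1H-pyrazol-3-yl in place of 1-methyl-1H-tetrazol-5-yl gives a number no higher from compound 1 to compound 4 (the limit leaves the size open). Going by these compounds alone, this is the first pair differing in this one place, and it shows that on this aromatic carbon the ring with two hetero atoms does not lose ground to the ring with four.

From the compounds shown here alone, the true size of this step remains unknown. Also open, going by these compounds, is how an amine or a carboxylic acid in this place would compare.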